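Methoxy for fluoro on the aryl substituent: cytotoxicity notes

This account rests on a few compounds, and the source may have more. Where it says the series, first, only, none or still open, it means among the compounds named here.

Compound 1 `CC(=O)c1cc(-c2ccccc2)cc2cc(-c3ccc(F)cc3)[nH]c12` gives 96.8% in a functional assay on MCF7 cells (Homo sapiens) for cytotoxicity, read by MTT assay, with a stated time of 2 days, tested at 1 uM (a lower number here means a stronger effect, a higher number a weaker effect of the compound at the concentration tested), the highest of the three measured numbers. Compound 2 `CC(=O)c1cc(-c2ccc(F)cc2)cc2cc(-c3ccc(F)cc3)[nH]c12` shares the core of compound 1, which differs from it by hydrogen in place of fluoro on an aromatic carbon. In this assay compound 2 gives 93.2%; the step of a number 3.6 percentage points lower from compound 1 to compound 2 (within the scatter) is within the scatter. Compound 3 `COc1ccc(-c2cc(C(C)=O)c3[nH]c(-c4ccc(F)cc4)cc3c2)cc1` gives 69.7%, reached by methoxy in place of fluoro on an aromatic carbon with the step of a number 23.5 percentage points lower from compound 2 to compound 3 (beyond the scatter), and by a number 27.1 percentage points lower from compound 1 to compound 3 (beyond the scatter) from compound 1.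

Compound 4 `COc1ccc(-c2cc3cc(-c4ccccc4)cc(C(C)=O)c3[nH]2)cc1` is not yet measured; it differs from compound 1 by methoxy in place of fluoro on an aromatic carbon, the same change as that from compound 2 to compound 3, at the same place. Resting on the measured pair, the step of a number 22.8 percentage points lower from compound 1 to compound 4 (beyond the scatter) is expected to be of similar size because a number 23.5 percentage points lower from compound 2 to compound 3 (beyond the scatter) is the only precedent. Compound 4 is therefore estimated at 74%, between 58% and 90%.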

Compound 4, a percentage reported as activity, at one concentration (the size of the read-out at that concentration, not a potency): 78.1%
Estimate against measurement, compound 4: 4.1 percentage points below; the range from low to high includes it.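

In this assay, the change from 4-fluorophenyl to 4-methoxyphenyl gives a number 18.7 percentage points lower from compound 1 to compound 4 (beyond the scatter), so the direction seen earlier recurs. The two steps do not differ in size: the same change on two cores in this assay, a number 23.5 percentage points lower (beyond the scatter) from compound 2 to compound 3 and a number 18.7 percentage points lower (beyond the scatter) from compound 1 to compound 4, 4.8 percentage points apart, within the scatter of two such steps. This supports carrying the change across these two cores only; two pairs at a single concentration give no potency, say nothing about why the number falls and do not predict the step on a third core.

The compounds shown leave open whether an amine, a carboxylic acid or a longer chain in place of methoxy would lower the number further. Also open, going by these compounds, is whether the step would keep its size at other concentrations.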